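Ring Size Change Carried Over to a Second Core

The source may report more compounds than this note shows. Statements on the series, on what has been measured and on what is new or still open speak of the compounds shown alone.

Three compounds share a common core. Compound 1 `CCNS(=O)(=O)c1ccc(NC2CCCC2)c(N)c1` gives 82 nM in a functional assay (IMR-32 cells, Homo sapiens) for inhibition, read by fluorescence, with stated times of 1 h and 13 h; on this read-out higher numbers stand for weaker inhibition and lower numbers for stronger inhibition. Compound 2 `CCNS(=O)(=O)c1ccc(NC2CCCCC2)c(N)c1` differs from it by cyclohexyl in place of cyclopentyl on a nitrogen on an aromatic ring; in this assay compound 2 gives 67 nM, a step of a 1.2-fold lower number from compound 1 to compound 2 (0.09 log units; within the scatter). Compound 3 `CCNS(=O)(=O)c1ccc(NC2CCCC2)c(NCc2ccncc2)c1` differs from compound 1 by (pyridin-4-yl)methyl in place of hydrogen on a nitrogen on an aromatic ring, and in this assay compound 3 gives 36 nM, a step of a 2.3-fold lower number from compound 1 to compound 3 (0.36 log units; beyond the scatter). Compound 4 `CCNS(=O)(=O)c1ccc(NC2CCCCC2)c(NCc2ccncc2)c1` is not yet measured; it differs from compound 3 by cyclohexyl in place of cyclopentyl on a nitrogen on an aromatic ring, the same change, at the same place, as from compound 1 to compound 2. That earlier step was small, so the step to compound 4 is expected to be similar, a 1.2-fold lower number from compound 3 to compound 4 (0.08 log units; within the scatter), because a 1.2-fold lower number from compound 1 to compound 2 (0.09 log units; within the scatter) stayed within the usual scatter. Compound 4 is therefore estimated at 30 nM, with a likely range from 15 nM to 60 nM.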

Compound 4, half-maximal inhibitory concentration: 23 nM
Beside the measured number, compound 4's estimate is 1.3-fold (0.12 log units) above it, and the stated range covers the measured number.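

In this assay, putting cyclohexyl in place of cyclopentyl gives a 1.6-fold lower number from compound 3 to compound 4 (0.19 log units; within the scatter), and this matches the step on the other core: the same change on two cores in this assay, a 1.2-fold lower number (0.09 log units; within the scatter) from compound 1 to compound 2 and a 1.6-fold lower number (0.19 log units; within the scatter) from compound 3 to compound 4, 1.3-fold (0.11 log units) apart, within the scatter of two such steps Adding (pyridin-4-yl)methyl gives a 2.9-fold lower number from compound 2 to compound 4 (0.46 log units; beyond the scatter), which also matches its counterpart: the same change on two cores in this assay, a 2.3-fold lower number (0.36 log units; beyond the scatter) from compound 1 to compound 3 and a 2.9-fold lower number (0.46 log units; beyond the scatter) from compound 2 to compound 4, 1.3-fold (0.11 log units) apart, within the scatter of two such steps So in these four compounds each change keeps its size from one core to the other, but each comparison rests on a single pair of steps, and this does not show that the same would hold on other cores or with other groups.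

The compounds shown leave open what a cyclobutyl ring or an open chain such as isobutyl would do in place of the cyclohexyl. They also leave open whether a benzyl group would match (pyridin-4-yl)methyl.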